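This account rests on a few compounds, and the source may have more. Where it says the series, first, only, none or still open, it means among the compounds named here.

Compound 1 `Cc1cccc(-n2nncc2CN2C(=O)C3(C(C#N)=C(N)Oc4c3c3nc5ccccc5nc3c3ccccc43)c3ccccc32)c1`: > 50000 nM
Compound 2 `N#CC1=C(N)Oc2c(c3nc4ccccc4nc3c3ccccc23)C12C(=O)N(Cc1cnnn1-c1ccc(F)cc1)c1ccccc12`: > 50000 nM
Compound 3 `COc1ccc(-n2nncc2CN2C(=O)C3(C(C#N)=C(N)Oc4c3c3nc5ccccc5nc3c3ccccc43)c3ccccc32)cc1`: > 50000 nM

All three measured compounds share one core and differ only in the aryl group on the aromatic nitrogen. In an ADME assay on L02 cells (Homo sapiens) for antiproliferative activity, read by MTT assay, with a stated time of 48 h (on this read-out higher numbers stand for weaker inhibition and lower numbers for stronger inhibition), none of them yields a number. For compound 1 the value > 50000 nM is a limit of the assay. For compound 2 the value > 50000 nM is likewise a limit. For compound 3 the value > 50000 nM is a limit as well. Accordingly the three steps between them cannot be read: a step that the two limits leave unreadable from compound 1 to compound 2, a step that the two limits leave unreadable from compound 1 to compound 3 and a step that the two limits leave unreadable from compound 2 to compound 3. Among the measured compounds shown here, the only evidence on the measured set is the limit of > 50000 nM in this assay, at which 3 of the 3 values shown sit.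

Compound 4 `N#CC1=C(N)Oc2c(c3nc4ccccc4nc3c3ccccc23)C12C(=O)N(Cc1cnnn1-c1cccc(S(N)(=O)=O)c1)c1ccccc12` follows from compound 2 by the change (3-sulfamoylphenyl in place of 4-fluorophenyl on an aromatic nitrogen). The steps from compound 1 to compound 2 and from compound 2 to compound 3 change the same aryl group at the same place, so they are the ones that bear on this change, but their size is not readable. With every measured compound sitting at the limit, no direction of change can be expected from the data. Compound 4 is therefore expected to remain near the limit, at an estimated 50000 nM, within 20000 nM to 120000 nM. The expected step of a number no higher from compound 2 to compound 4 (the limit leaves the size open) is accordingly estimated as none beyond the scatter.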

Compound 4, half-maximal inhibitory concentration: > 50000 nM
Compound 4: only a limit was reported; the forecaster's own chance of this, stated with the estimate: 80%; the middle value sits exactly at the limit.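

In this assay compound 4 gives > 50000 nM, which is a limit of the assay and not a number. No step between compound 4 and compounds 1, 2 or 3 can be read: the limit of > 50000 nM in this assay, at which 4 of the 4 values shown sit.

The compounds shown leave open whether any of these aryl groups on the aromatic nitrogen changes the read-out, and by how much.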